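Changing One Aromatic Ring in a Growth-Inhibition Series

The compounds below may be only part of what the source reports. "The series", "measured", "known", "first", "only" and "open" are said of these compounds alone.

Of the compounds shown here, two from this study have so far been tested in a functional assay on DU-145 cells (Homo sapiens) for inhibition, read by trypan blue exclusion, with a stated time of 96 h; a higher number here means a weaker inhibitor of growth, a lower number a stronger inhibitor of growth. Compound 1, with the structure `Cc1ccc(S/C(=C/c2ccc(Br)cc2)C(=O)c2ccc(Cl)cc2)cc1`, gives 25000 nM in this assay, the highest of the two numbers seen, so it is the weaker grower-inhibitor of the pair. Compound 2, `Cc1ccc(CS/C(=C/c2ccc(Br)cc2)C(=O)c2ccc(Cl)cc2)cc1`, gives 10000 nM in this assay. Among the measured compounds shown here, the single measured step between them, a 2.5-fold lower number from compound 1 to compound 2 (0.40 log units; beyond the scatter), comes from a change on a sulfur, 4-methylbenzyl in place of 4-methylphenyl.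

Compound 3, `COc1ccccc1/C=C(/Sc1ccc(C)cc1)C(=O)c1ccc(Cl)cc1`, has not yet been measured. It differs from compound 1 at another place: 2-methoxyphenyl in place of 4-bromophenyl on a double-bonded chain carbon bound to a double-bonded chain carbon. For the measured compounds named here, the one measured step, from compound 1 to compound 2, alters the group on the sulfur and leaves the ring on the double-bonded chain carbon untouched, so it gives no direct guide to this new change. Without a bearing step, no shift beyond the scatter is expected in either direction, and the estimate is set close to the value of compound 1 with a wide range. Compound 3 is therefore expected to give 25000 nM in this assay, within 8000 nM to 80000 nM. The expected step is no change at the digits printed from compound 1 to compound 3 (within the scatter).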

Compound 3, concentration for 50% growth inhibition: 25000 nM
The estimate for compound 3 equals the measured number at the digits printed; the range from low to high includes it.
By their numbers in this assay, from the lowest: compound 2; then compounds 1 and 3 (each within the scatter of the next).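

In this assay, putting 2-methoxyphenyl in place of 4-bromophenyl on a double-bonded chain carbon bound to a double-bonded chain carbon gives no change at the digits printed from compound 1 to compound 3 (within the scatter), so this exchange of rings does not separate the two compounds, even though the bromine leaves and an oxygen enters, with one hydrogen-bond acceptor by the count. This is the first look at the ring at this place, since the earlier step, a 2.5-fold lower number from compound 1 to compound 2 (0.40 log units; beyond the scatter), concerned only the group on the sulfur, and that step remains the only one shown that lies beyond the scatter. No separate measurement is available to explain why these two numbers lie within the scatter of each other.

The exchange alters both the substituent on the ring and where it sits, so these compounds cannot show whether either alone would matter, or whether 2-methoxyphenyl would give a similar result alongside the 4-methylbenzyl group of compound 2. On these data alone, it also remains open whether a ring carrying an amine or a carboxylic acid at this place would differ from compound 1 by more than the scatter.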